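This account rests on a few compounds, and the source may have more. Where it says the series, first, only, none or still open, it means among the compounds named here.

Measured so far in a functional assay on MDA-MB-231 cells (Homo sapiens) for inhibition, read by MTT assay, with a stated time of 48 h; a higher number here means a weaker inhibitor, a lower number a stronger inhibitor:
compound 1 `COc1cc(-c2cc(/C=C/C(=O)c3ccc(N)cc3)[nH]n2)cc(OC)c1OC` — 2000 nM
compound 2 `COc1cc(-c2cc(/C=C3\CCc4ccccc4C3=O)[nH]n2)cc(OC)c1OC` — 9500 nM

Compound 1 gives the lowest number of the two; compound 2 sits higher by a gap beyond the scatter, and no single-point comparison between the two is available. Compound 3 `COc1cc(-c2cc(/C=C/C(=O)c3ccc(F)c(F)c3)[nH]n2)cc(OC)c1OC` is the next point: 3,4-difluorophenyl in place of 4-aminophenyl on a carbonyl carbon. Among the compounds with values here, no measured pair isolates this change, so the direction rests on no precedent. The step of a 1.8-fold higher number from compound 1 to compound 3 (0.24 log units; within the scatter) is expected to be small and toward a weaker inhibitor. For compound 3 in this assay the estimate is 3500 nM, within 1200 nM to 11000 nM.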

Compound 3, half-maximal inhibitory concentration: 1500 nM
Compound 3: the middle estimate sits 2.3-fold (0.37 log units) above what was measured; the measured number falls inside the stated range.
By their numbers in this assay, from the lowest: compounds 3 and 1 (each within the scatter of the next); then compound 2.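

Replacing 4-aminophenyl with 3,4-difluorophenyl on a carbonyl carbon gives a 1.3-fold lower number from compound 1 to compound 3 (0.12 log units; within the scatter) in this assay. This position therefore accepts the change without a step beyond the scatter, even though the hydrogen-bond donor and acceptor counted on 4-aminophenyl are absent from 3,4-difluorophenyl. No supporting measurement bears on why the two groups read alike.

Still open, from the compounds shown here alone, is whether unsubstituted phenyl, 4-fluorophenyl or 4-hydroxyphenyl at this position would also stay within the scatter of compound 1. Going by these compounds, a larger group, such as a morpholine on the phenyl ring, also remains untested here.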